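A few compounds are considered here, and "the series" means these few. Any claim that something is new, unique, unknown or untested is made for them only; others in the source may bear on it.

Compound 1 `CC(C)NC(=O)[C@H]1CC[C@@H](n2/c(=N/C(=O)c3cccnc3)[nH]c3ccc(CN4CCC(C(C)(C)O)CC4)cc32)CC1` gives in an in vitro ADME assay on microsomes from liver (Rattus norvegicus) for metabolic stability (a higher number here means faster removal of the compound, a lower number slower removal), only a limit of the assay, < 14 mL.min-1.g-1 (the limit of < 14 mL.min-1.g-1 in this assay, at which 1 of the 3 values shown sits). Compound 2 `CC(C)NC(=O)[C@H]1CC[C@@H](n2/c(=N/C(=O)c3ccc(F)c(Cl)c3)[nH]c3ccc(CN4CCC(C(C)(C)O)CC4)cc32)CC1` gives 44 mL.min-1.g-1, and compound 3 `CC(C)NC(=O)[C@H]1CC[C@@H](n2/c(=N/C(=O)c3cc(F)cc(C#N)c3)[nH]c3ccc(CN4CCC(C(C)(C)O)CC4)cc32)CC1` gives 30 mL.min-1.g-1; these two sit within the scatter of each other, the step being a 1.5-fold lower number from compound 2 to compound 3 (0.17 log units; within the scatter). Both are set apart from compound 1, as an at least 3.1-fold higher number from compound 1 to compound 2 (0.49 log units; beyond the scatter) and an at least 2.1-fold higher number from compound 1 to compound 3 (0.33 log units; beyond the scatter) show. Compound 4 `CC(C)NC(=O)[C@H]1CC[C@@H](n2/c(=N/C(=O)c3cc(F)cc(Cl)c3)[nH]c3ccc(CN4CCC(C(C)(C)O)CC4)cc32)CC1` differs from compound 3 by chloro in place of cyano on an aromatic carbon. The nearest guide is the change between compound 2 and compound 3, which stayed within the scatter, so no step beyond the scatter is expected in this assay. Compound 4 is therefore estimated at 38 mL.min-1.g-1, between 20 mL.min-1.g-1 and 75 mL.min-1.g-1, a step of a 1.3-fold higher number from compound 3 to compound 4 (0.10 log units; within the scatter).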

Compound 4, intrinsic clearance in microsomes: 43 mL.min-1.g-1
The estimate for compound 4 lay 1.1-fold (0.05 log units) below the measured number; the measured number falls inside the stated range.
By their numbers in this assay, from the lowest: compounds 3, 4 and 2 (each within the scatter of the next). At a limit, below all of these: compound 1.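

In this assay, chloro and cyano at this place, meta to a fluoro group, are not told apart (a 1.4-fold higher number from compound 3 to compound 4 (0.16 log units; within the scatter)). Changing 3-chloro-4-fluorophenyl to 3-chloro-5-fluorophenyl likewise leaves the number within the scatter (a 1.0-fold lower number from compound 2 to compound 4 (0.01 log units; within the scatter)). The gap to the pyridin-3-yl group of compound 1, whose value is a limit of the assay, also holds for this third phenyl group (an at least 3.0-fold higher number from compound 1 to compound 4 (0.48 log units; beyond the scatter)).

On these data alone, whether a methoxy group or an amine at this place would stay within the scatter remains open. So does whether chloro on the pyridin-3-yl ring would keep the number at the limit seen for compound 1.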